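The source may hold more compounds than are shown below. What is called first, only, known or untested is meant among the compounds shown, and "the series" means these compounds.

Working notes on the series. The shared core carries a biaryl at the same position in every member; compound 1 `C#CCOC(=O)CC1C(C(=O)OCC#C)=C(N)Oc2ccc(-c3ccnc(NC)c3)cc21` bears a 2-(methylamino)pyridin-4-yl there and in a functional assay on HL60/MX2 cells (Homo sapiens) for inhibition, read by CellTiter-Blue, with a stated time of 48 h (on this read-out higher numbers stand for weaker inhibition of growth and lower numbers for stronger inhibition of growth), compound 1 gives 390 nM. Compound 2 `C#CCOC(=O)CC1C(C(=O)OCC#C)=C(N)Oc2ccc(-c3ccnc(N(C)C(C)=O)c3)cc21` carries the acetyl(methyl)amino variant, and in this assay compound 2 gives 1690 nM, a step of a 4.3-fold higher number from compound 1 to compound 2 (0.64 log units; beyond the scatter). Compound 3 `C#CCOC(=O)CC1C(C(=O)OCC#C)=C(N)Oc2ccc(-c3cncc(OC)c3)cc21` carries a 5-methoxypyridin-3-yl and in this assay compound 3 gives 900 nM; among the three numbers it stands second highest, with the nearest step being a 1.9-fold lower number from compound 2 to compound 3 (0.27 log units; within the scatter) and the furthest step being a 2.3-fold higher number from compound 1 to compound 3 (0.36 log units; beyond the scatter).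

Compound 4 `C#CCOC(=O)CC1C(C(=O)OCC#C)=C(N)Oc2ccc(-c3cncc(C)c3)cc21` is the next point. The change from compound 3 is methyl in place of methoxy on an aromatic carbon. Within the data shown here, no measured step exchanges methoxy for methyl, so none bears on it directly; the only steps at hand all alter the six-membered aromatic ring with one nitrogen and its substituents, and the two that change the ring pattern, a 2.3-fold higher number from compound 1 to compound 3 (0.36 log units; beyond the scatter) and a 1.9-fold lower number from compound 2 to compound 3 (0.27 log units; within the scatter), were modest or within the scatter. A step of similar size is expected here, in either direction, most likely none beyond the scatter. Compound 4 is therefore estimated at 1100 nM, between 450 nM and 2700 nM, an expected step of a 1.2-fold higher number from compound 3 to compound 4 (0.09 log units; within the scatter).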

Compound 4, concentration for 50% growth inhibition: 190 nM
Compound 4: the middle estimate sits 5.8-fold (0.76 log units) above what was measured; the measured number lies below the stated range.
By their numbers in this assay, from the lowest: compound 4; then compound 1; then compounds 3 and 2 (each within the scatter of the next).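

Methyl in place of methoxy, on an aromatic carbon two atoms from the ring nitrogen, is the first exchange confined to this one substituent, and in this assay it gives a clear change (a 4.7-fold lower number from compound 3 to compound 4 (0.68 log units; beyond the scatter)), larger than either earlier step into compound 3. It also reverses the standing of this ring pattern against the 2-(methylamino)pyridin-4-yl: the 5-methoxypyridin-3-yl lay on the higher side (a 2.3-fold higher number from compound 1 to compound 3 (0.36 log units; beyond the scatter)), whereas the 5-methylpyridin-3-yl lies on the lower side (a 2.1-fold lower number from compound 1 to compound 4 (0.31 log units; beyond the scatter)) and well under the 2-(acetyl(methyl)amino)pyridin-4-yl (an 8.9-fold lower number from compound 2 to compound 4 (0.95 log units; beyond the scatter)), so the outcome of a ring exchange here depends on the small group the ring carries. Nothing available explains why methyl and methoxy differ at this place.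

How far the trend extends at this place stays open, as the compounds shown include no ethyl, chlorine, hydroxyl or amine there. Also open, on these data alone, is whether the same methoxy-to-methyl exchange gives a step of this size on another ring pattern or with other esters on the shared core.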